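This account rests on a few compounds, and the source may have more. Where it says the series, first, only, none or still open, it means among the compounds named here.

Compound 1 `Cc1ccnc(NC(c2ccc(F)cc2)c2ccc3cccnc3c2O)c1` is the starting point of this small set. In an assay for inhibition of protein disulfide-isomerase (Homo sapiens), with a stated time of 1 h (on this read-out lower numbers stand for stronger inhibition and higher numbers for weaker inhibition), compound 1 gives 140 nM. Compound 3 `Cc1ccnc(NC(c2ccc([N+](=O)[O-])cc2)c2ccc3cccnc3c2O)c1` differs from it in one place only, (nitro in place of fluoro on an aromatic carbon), and in this assay compound 3 gives 530 nM, so that a 3.8-fold higher number from compound 1 to compound 3 (0.58 log units; beyond the scatter).

Compound 2 `Oc1ccc2[nH]ncc2c1C(c1ccc(F)cc1)N1CCCCC1` is built on a different core; the difference between the two cores is not broken down here. In this assay compound 2 gives 350 nM, which puts it between the other two measured compounds.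

Compound 4 `O=[N+]([O-])c1ccc(C(c2c(O)ccc3[nH]ncc23)N2CCCCC2)cc1` has not yet been measured. It stands to compound 2 as compound 3 stands to compound 1: nitro in place of fluoro on an aromatic carbon. The place where the change happens is described in the same words for both pairs, so this is the same change applied to a second core. Because the earlier step of a 3.8-fold higher number from compound 1 to compound 3 (0.58 log units; beyond the scatter) weakened inhibition, a step of similar size is expected here, a 3.4-fold higher number from compound 2 to compound 4 (0.54 log units; beyond the scatter). On that basis compound 4 is estimated to give about 1200 nM, most likely between 500 nM and 3000 nM.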

Compound 4, half-maximal inhibitory concentration: 520 nM
Compound 4: middle estimate off by 2.3-fold (0.36 log units), on the high side; the measured number falls inside the stated range.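

On the core of compound 2, nitro in place of fluoro gives a 1.5-fold higher number from compound 2 to compound 4 (0.17 log units; within the scatter), so compound 2 and compound 4 cannot be told apart in this assay. Set beside the step on the core of compound 1, which does lie beyond the scatter, the gap between the two steps is no larger than repeated measurements could produce: the same change on two cores in this assay, a 3.8-fold higher number (0.58 log units; beyond the scatter) from compound 1 to compound 3 and a 1.5-fold higher number (0.17 log units; within the scatter) from compound 2 to compound 4, 2.5-fold (0.41 log units) apart, within the scatter of two such steps. Among these compounds, this shows no measurable difference in how the change behaves on the two cores, but it does not show that the change carries over unchanged, since there are only two pairs and the second step on its own is too small to read.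

The compounds shown carry only fluoro and nitro at this place, para to a large group, so what a chlorine, a methoxy group or an amine would do there on either core stays open. Going by these compounds, whether the change would behave in the same way on a third core also stays open.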